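Swapping a bicyclic amide for a pyridine in a weak compound

This account rests on a few compounds, and the source may have more. Where it says the series, first, only, none or still open, it means among the compounds named here.

Compound 1 `COc1cccc(OC)c1C(=O)Nc1c[nH]nc1C(=O)NC1CC2CCC1C2` is the starting point. In an ADME assay on MRC5 cells (Homo sapiens) for inhibition, with a stated time of 72 h (a lower number here means that less compound is needed, a higher number that more compound is needed for the effect), compound 1 gives only > 50000 nM, a limit of the assay rather than a measured number, so its activity is known only to lie beyond the range tested (the limit of > 50000 nM in this assay, at which 1 of the 3 values shown sits). Two related compounds with a different amide partner were measured: compound 2 `CO[C@H]1CC[C@H](NC(=O)c2n[nH]cc2NC(=O)c2ccccc2C(F)(F)F)CC1` gives 3300 nM, and compound 3 `CO[C@H]1CC[C@H](NC(=O)c2n[nH]cc2NC(=O)c2cc3ccccn3n2)CC1` gives 1000 nM in this assay. The step to the unmeasured compound 4 `COc1cccc(OC)c1C(=O)Nc1c[nH]nc1C(=O)Nc1ccccn1` changes the other end of the core of compound 1: a group of 6 heavy atoms (5 carbon, 1 nitrogen; one six-membered aromatic ring with 1 hetero atom) in place of a group of 7 heavy atoms (7 carbon; 2 five-membered non-aromatic rings of carbon only), on an amide-type nitrogen. Within the data shown here, no measured pair shows this particular exchange, so the size of its effect is open. With compound 1 sitting at the limit, the change in this assay can hardly go in the weaker direction; a step toward somewhat more potency is expected, but a large one is not, and the result may again be a limit. Compound 4 is therefore estimated at 25000 nM, within a range of 4000 nM to 50000 nM. This estimate means a step of an at least 2.0-fold lower number from compound 1 to compound 4 (0.30 log units; that floor lies within the scatter).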

Compound 4, half-maximal effective concentration: > 50000 nM
Compound 4 ended at the assay's limit (the forecaster's own chance of this, stated with the estimate: 50%); middle value at least 2.0-fold (0.30 log units) from the limit.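

No size can be read for the step between compound 1 and compound 4, because each result is only a limit and not a number: the limit of > 50000 nM in this assay, at which 2 of the 4 values shown sit.

The compounds shown leave open whether pyridin-2-yl in place of the original group changes the result in this assay at all.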